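The compounds below may be only part of what the source reports. "The series", "measured", "known", "first", "only" and "open" are said of these compounds alone.

Series notes. Compound 1 `CNC(=O)/C=C/c1ccncc1-c1ccc2cccnc2c1` and compound 3 `O=C(/C=C/c1ccncc1-c1ccc2cccnc2c1)N1CCOCC1` share one core; compound 2 `O=C(/C=C/c1ccncc1-c1ccc2ncccc2c1)N1CCOCC1` and compound 4 `CNC(=O)/C=C/c1ccncc1-c1ccc2ncccc2c1` share another. The difference between the two cores is not broken down here.

In an assay on a protein complex for inhibition of CDK8/Cyclin C (Homo sapiens), with a stated time of 1 h, tested at 10 uM (a higher number here means more inhibition at the concentration tested (going by the name of the read-out), a lower number less inhibition), compound 1 gives 82%, compound 2 gives 80% and compound 3 gives 33%. The change methylamino in place of morpholin-4-yl on a carbonyl carbon made the step of a number 49 percentage points higher from compound 3 to compound 1 (beyond the scatter).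

The same change is now made on the second core, (methylamino in place of morpholin-4-yl on a carbonyl carbon). A step of that size is not expected again, because compound 2 already gives 80% and the read-out cannot rise far above that. The step from compound 2 to compound 4 is estimated as a number 5 percentage points higher from compound 2 to compound 4 (within the scatter). Compound 4 is therefore expected to give about 85%, in the range 70% to 96%.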

Compound 4, a percentage reported as inhibition, at one concentration (the size of the read-out at that concentration, not a potency): 97%
For compound 4 the middle estimate is 12 percentage points below the measured one; measured number outside the range, above it.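

In this assay the change to methylamino in place of morpholin-4-yl on a carbonyl carbon holds its direction on the second core, with a number 17 percentage points higher from compound 2 to compound 4 (beyond the scatter). The size of the step does not carry over between the two cores: the same change on two cores in this assay, a number 49 percentage points higher (beyond the scatter) from compound 3 to compound 1 and a number 17 percentage points higher (beyond the scatter) from compound 2 to compound 4, 32 percentage points apart, beyond the scatter of two such steps

Among these compounds, two pairs show agreement in sign only, and they do not show whether the gap in size belongs to the cores or to the read-out, as this single-concentration percentage is no potency and the steps start from different values, compound 3 at 33% and compound 2 at 80%.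

The compounds shown leave open whether the rise follows the amide hydrogen or the loss of the morpholine ring. A dimethylamino or a piperidin-1-yl group on the same carbonyl carbon would bear on that question.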